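Working notes on the shared core: compound 2 to compound 3

This account rests on a few compounds, and the source may have more. Where it says the series, first, only, none or still open, it means among the compounds named here.

compound 1 `O=C(/C=C\c1ccccc1)N1N=C(c2ccncc2)OC1c1c[nH]c2ccccc12` — in an ADME assay on PANC-1 cells (Homo sapiens) for cytotoxicity, read by MTT assay, with a stated time of 48 h (a higher number here means a weaker inhibitor of growth, a lower number a stronger inhibitor of growth), a limit only: > 30 ug/mL
compound 2 `O=C(/C=C\c1ccccc1O)N1N=C(c2ccncc2)OC1c1c[nH]c2ccccc12` — in this assay a limit only: > 30 ug/mL

Compound 1 gives no number in this assay, only the limit > 30 ug/mL. Compound 2 likewise reaches only the limit > 30 ug/mL. Among the measured compounds shown here, the one step between them, a step that the two limits leave unreadable from compound 1 to compound 2, is therefore unreadable in size, and both values sit at the limit of > 30 ug/mL in this assay, at which 2 of the 2 values shown sit. Compound 2 thus stands at the limit of this assay and nowhere more precise.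

Compound 3 `O=C(/C=C\c1cccc(Cl)c1)N1N=C(c2ccncc2)OC1c1c[nH]c2ccccc12` is the next entry. Relative to compound 2 the change is 3-chlorophenyl in place of 2-hydroxyphenyl on a double-bonded chain carbon bound to a double-bonded chain carbon. For the measured compounds named here, no measured step bears on this change: the only step in hand is unreadable, so there is no basis for expecting a step beyond the scatter in either direction. Compound 3 is expected at 40 ug/mL, within 12 ug/mL to 120 ug/mL, an expected step that the limit leaves unreadable from compound 2 to compound 3.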

Compound 3, concentration for 50% growth inhibition: > 30 ug/mL
Compound 3: only a limit was reported; the forecaster's own chance of this, stated with the estimate: 65%; the middle value is on the limit's open side.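

No new step can be read among compound 1, compound 2 and compound 3, because all three stop at the same limit: the limit of > 30 ug/mL in this assay, at which 3 of the 3 values shown sit.

The compounds shown leave open how far each lies beyond that limit, and whether either change on the shared core alters growth inhibition.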